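Small Methyl Additions and Cell Toxicity Across Four Compounds

This account rests on a few compounds, and the source may have more. Where it says the series, first, only, none or still open, it means among the compounds named here.

Compound 1 `CN(C)c1nc(Cc2c(F)cccc2F)cc(=O)[nH]1`: > 94000 nM
Compound 2 `CC(c1cc(=O)[nH]c(N(C)C)n1)c1c(F)cccc1F`: 89000 nM
Compound 3 `Cc1c(C(C)c2c(F)cccc2F)nc(N(C)C)[nH]c1=O`: > 17000 nM

In an ADME assay on MT4 cells (Homo sapiens) for cytotoxicity, read by MTT assay, with a stated time of 4 days (on this read-out lower numbers stand for higher toxicity in this test and higher numbers for lower toxicity in this test), compound 1 returns only a limit, > 94000 nM. Compound 2 gives a measured value of 89000 nM in this assay. Compound 3 again reaches only a limit, > 17000 nM. The change from compound 1 to compound 2 is methyl in place of hydrogen on a saturated chain carbon bound to two aromatic carbons, and in this assay it produced an at least 1.0-fold lower number from compound 1 to compound 2 (0.02 log units; that floor lies within the scatter). The further change gave a step that the limit leaves unreadable from compound 2 to compound 3, because the limit of > 17000 nM in this assay, at which 1 of the 3 values shown sits, caps what can be read. The difference between the cores of compound 1 and compound 3 is not broken down here.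

Compound 4 `CCC(c1nc(N(C)C)[nH]c(=O)c1C)c1c(F)cccc1F` differs from compound 3 by methyl in place of hydrogen on a saturated chain carbon, two bonds along the chain from two aromatic carbons. This is the same kind of change as that from compound 1 to compound 2, but the carbon carrying it lies two bonds along the chain from two aromatic carbons rather than bound to two aromatic carbons. Given the flat step an at least 1.0-fold lower number from compound 1 to compound 2 (0.02 log units; that floor lies within the scatter) and the limit (the limit of > 17000 nM in this assay, at which 1 of the 3 values shown sits), the step from compound 3 to compound 4 is expected to be a step that the limit leaves unreadable from compound 3 to compound 4. Compound 4 is therefore estimated at 40000 nM, plausibly between 12000 nM and 120000 nM, with a fair chance that this assay again reports only a limit.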

Compound 4, half-maximal cytotoxic concentration: > 81000 nM
Compound 4 was reported as a limit; the forecaster's own chance of this, stated with the estimate: 60%; middle value at least 2.0-fold (0.30 log units) from the limit.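

Compound 4 is reported only as a limit, > 81000 nM, in this assay. Among the compounds shown here, compound 3 is also only a limit, > 17000 nM, so no step from compound 3 to compound 4 can be read. The compounds shown leave open whether this added methyl changes the half-maximal cytotoxic concentration at all.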